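From Difluoro to Dimethyl at the Edge of Clearance

The source may report more compounds than this note shows. Statements on the series, on what has been measured and on what is new or still open speak of the compounds shown alone.

Of the compounds shown here, two have so far been measured in an ADME assay on microsomes from liver (Homo sapiens) for metabolic stability, read by LC-MS, with a stated time of 40 min, tested at 0.5 uM (on this read-out lower numbers stand for slow clearance and higher numbers for fast clearance), and neither gives a number. Compound 1 (`O=C(Nc1cccc(S(=O)(=O)C2CCCC2)c1)c1cccnc1N1CCC(F)(F)CC1`) gives > 399 mL.min-1.g-1 as a limit of the assay and not as a value. Compound 2 (`CC(C)(CO)Nc1ccc(C(=O)Nc2cccc(S(=O)(=O)NC3CCCC3)n2)c(N2CCC3(CC2)CC3)c1`) gives > 399 mL.min-1.g-1 as a limit too. The whole record is thus the limit of > 399 mL.min-1.g-1 in this assay, at which 2 of the 2 values shown sit, and nothing finer.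

Compound 3 (`CC1(C)CCN(c2ncccc2C(=O)Nc2cccc(S(=O)(=O)C3CCCC3)c2)CC1`) is still to be measured. It carries 4,4-dimethylpiperidin-1-yl in place of the 4,4-difluoropiperidin-1-yl of compound 1 on an aromatic carbon (4,4-dimethylpiperidin-1-yl in place of 4,4-difluoropiperidin-1-yl on an aromatic carbon), at a place on a six-membered aromatic ring with 1 nitrogen, next to the ring nitrogen and ortho to a large group.

Going by the values given here, no two measured compounds differ in one place, so no step in this assay can be read from the data. Among the compounds with values here, the only guide is compound 1 at its limit of > 399 mL.min-1.g-1 for this reason, and no move towards slow clearance is expected. The expected step (a step that the limit leaves unreadable from compound 1 to compound 3) is none beyond the scatter. For compound 3 the estimated value is 450 mL.min-1.g-1 (expected range 250 mL.min-1.g-1 to 800 mL.min-1.g-1) and a further limit is the likeliest report.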

Compound 3, intrinsic clearance in microsomes: > 399 mL.min-1.g-1
Compound 3: no number, only a limit; the forecaster's own chance of this, stated with the estimate: 75%; the middle value lies beyond the limit too.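

No step between compound 1 and compound 3 can be read in this assay, because both give only a limit of the assay and not a number: the limit of > 399 mL.min-1.g-1 in this assay, at which 3 of the 3 values shown sit.

The compounds shown leave open how 4,4-dimethylpiperidin-1-yl and 4,4-difluoropiperidin-1-yl truly compare, and whether any compound in this series would give a measurable clearance value.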